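The source may hold more compounds than are shown below. What is called first, only, known or untested is meant among the compounds shown, and "the series" means these compounds.

Measured so far: compound 1, `C=C1CC[C@@H]2CCC3=C(C2(C)C)[C@@](O)(C/C(C)=C/[C@@H](O)C1)OC3=O`, > 50 ug/mL; compound 2, `C=C1CC[C@@H]2CCC3=C(C(=O)[C@@H](/C(C)=C/C(O)C1)[C@H]3O)C2(C)C`, > 50 ug/mL.

In a functional assay on HT-29 cells (Homo sapiens) for cytotoxicity, read by MTT assay, with a stated time of 6 days (a lower number here means that less compound is needed, a higher number that more compound is needed for the effect), compound 1 gives only a limit, > 50 ug/mL. In this assay compound 2 also gives only a limit, > 50 ug/mL. Compound 2 thus stands at the limit of > 50 ug/mL in this assay, at which 2 of the 2 values shown sit, with no number of its own. Compound 3, `C=C1CC/C=C(\C)[C@@H]2C(=O)C3=C(CC[C@@H](CC1)C3(C)C)[C@@H]2O`, differs from compound 2 by hydrogen in place of hydroxy on a saturated ring carbon. Going by the values given here, no measured step shows what this change does in this assay, so no shift beyond the scatter is expected in either direction. Compound 3 is expected to give 60 ug/mL, between 20 ug/mL and 200 ug/mL. That expectation means a step that the limit leaves unreadable from compound 2 to compound 3.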

Compound 3, concentration for half-maximal effect: > 50 ug/mL
Compound 3 gave a limit, no number; the forecaster's own chance of this, stated with the estimate: 75%; the middle value is on the limit's open side.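

In this assay compound 3 gives only the limit > 50 ug/mL and compound 2 likewise gives only a limit, so no step can be read between them. The compounds shown leave open whether hydrogen in place of hydroxy changes the concentration needed for the effect.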